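The source may report more compounds than this note shows. Statements on the series, on what has been measured and on what is new or still open speak of the compounds shown alone.

Compound 1 `CC(C)(C)C[C@@H](O)C(=O)N1C[C@@H]2C[C@@H]2[C@H]1C(=O)NCc1cc(Cl)ccc1-n1cnnn1`: 910 nM
Compound 2 `O=C(NCc1cc(Cl)ccc1-n1cnnn1)[C@@H]1[C@H]2C[C@H]2CN1C(=O)[C@H](O)Cc1ccccc1`: 1200 nM
Compound 3 `CC(C)(C)OC[C@@H](O)C(=O)N1C[C@@H]2C[C@@H]2[C@H]1C(=O)NCc1cc(Cl)ccc1-n1cnnn1`: 570 nM

These values come from a functional assay on a cell-free system (plasma, Homo sapiens), with a stated time of 3 min; a higher number here means a weaker inhibitor, a lower number a stronger inhibitor. Compound 3 cannot be separated from compound 1: a 1.6-fold lower number from compound 1 to compound 3 (0.20 log units; within the scatter). It does stand modestly apart from compound 2: a 2.1-fold lower number from compound 2 to compound 3 (0.32 log units; beyond the scatter). The third step between these compounds is a 1.3-fold higher number from compound 1 to compound 2 (0.12 log units; within the scatter). All three steps swap a group at the same place and all are small.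

Compound 4 `O=C(NCc1cc(Cl)ccc1-n1cnnn1)[C@@H]1[C@H]2C[C@H]2CN1C(=O)[C@H](O)CC1CC1` puts cyclopropyl in place of tert-butoxy on a saturated chain carbon, two bonds along the chain from a carbonyl carbon and an oxygen on a saturated carbon. Among the measured compounds shown here, no measured compound carries cyclopropyl, so the range must stay wide. Compound 3 alone carries tert-butoxy, while the other groups gave compound 1 910 nM and compound 2 1200 nM, so a small move towards those values is expected. The expected change is a 1.8-fold higher number from compound 3 to compound 4 (0.24 log units; within the scatter). The estimated value for compound 4 is 1000 nM, with an expected range from 400 nM to 2500 nM.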

Compound 4, half-maximal inhibitory concentration: 1400 nM
Compound 4: the middle estimate sits 1.4-fold (0.15 log units) below what was measured; measured number inside the range.
By their numbers in this assay, from the lowest: compounds 3, 1, 2 and 4 (each within the scatter of the next, the first and the last beyond it).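

Putting cyclopropyl in place of tert-butoxy gives a real but modest step, a 2.5-fold higher number from compound 3 to compound 4 (0.39 log units; beyond the scatter), while cyclopropyl cannot be told apart from phenyl, a 1.2-fold higher number from compound 2 to compound 4 (0.07 log units; within the scatter), or from tert-butyl, a 1.5-fold higher number from compound 1 to compound 4 (0.19 log units; within the scatter). Compound 3 now stands apart from two of the other three compounds, though still not from compound 1, so this position responds only slightly to the four groups tried. Nothing available explains these small differences. As far as these compounds go, whether an amine or a carboxylic acid here would give a larger step remains open, as does the effect of a longer chain.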